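Fluoro to chloro swap on the trimethoxy analogue

The source may hold more compounds than are shown below. What is called first, only, known or untested is meant among the compounds shown, and "the series" means these compounds.

Measured so far:
compound 1 `COc1cc(Cn2cc(CNC(=O)c3cn(-c4ccccc4)nc3-c3ccc(F)cc3)nn2)cc(OC)c1`: 360 nM
compound 2 `COc1cc(Cn2cc(CNC(=O)c3cn(-c4ccccc4)nc3-c3ccc(F)cc3)nn2)cc(OC)c1OC`: 2100 nM

In a functional assay on HeLa cells (Homo sapiens) for antiproliferative activity, read by sulforhodamine B assay, with a stated time of 48 h (on this read-out lower numbers stand for stronger inhibition of growth and higher numbers for weaker inhibition of growth), compound 1 gives 360 nM, and compound 2 gives 2100 nM. For the measured compounds named here, compound 2 stands at the higher of the two numbers; the only step recorded is a 5.8-fold higher number from compound 1 to compound 2 (0.77 log units; beyond the scatter), which is methoxy in place of hydrogen on an aromatic carbon.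

Compound 3 `COc1cc(Cn2cc(CNC(=O)c3cn(-c4ccccc4)nc3-c3ccc(Cl)cc3)nn2)cc(OC)c1OC` differs from compound 2 by chloro in place of fluoro on an aromatic carbon. Going by the values given here, no measured pair bears on a fluoro-to-chloro exchange; the single recorded step concerns a different position and a different group, so it gives no direction for this change. The expectation is therefore a step of no more than the usual scatter in this assay, with the estimate for compound 3 set close to compound 2: a 1.1-fold lower number from compound 2 to compound 3 (0.02 log units; within the scatter), giving an expected value of 2000 nM, within 800 nM to 5000 nM.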

Compound 3, concentration for 50% growth inhibition: 100 nM
Estimate against measurement, compound 3: 20-fold (1.30 log units) above; the measured number lies below the stated range.
By their numbers in this assay, from the lowest: compound 3; then compound 1; then compound 2.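

In this assay the exchange of 4-fluorophenyl to 4-chlorophenyl gives a 21-fold lower number from compound 2 to compound 3 (1.32 log units; beyond the scatter) and marks this halogen, on an aromatic carbon para to a large group, as a sensitive point in the trimethoxy analogue. The earlier compounds shown here showed only the response to methoxy in place of hydrogen on the other aromatic ring, with a 5.8-fold higher number from compound 1 to compound 2 (0.77 log units; beyond the scatter) as a modest step, whereas this large step shows that the halogen-bearing ring also strongly affects growth inhibition. Nothing available here gives a measured basis for explaining the size of this step.

From the compounds shown here alone, whether chloro brings a similar gain in the dimethoxy analogue, compound 1, remains open. Also open, going by these compounds, is how bromo, methyl or an amine in the same place would compare with chloro on the shared core.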